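A few compounds are considered here, and "the series" means these few. Any claim that something is new, unique, unknown or untested is made for them only; others in the source may bear on it.

Compound 2 `COc1ccc2c(c1)O/C(=C\c1ccc(OCCCN(C)C)cc1)C2=O` gives 895 nM in an assay on isolated protein for inhibition of Amine oxidase [flavin-containing] B (Homo sapiens), read by spectrophotometry, with a stated time of 30 min (on this read-out higher numbers stand for weaker inhibition and lower numbers for stronger inhibition), and it stands level with compound 1 `CCN(CC)c1ccc(/C=C2\Oc3cc(OC)ccc3C2=O)cc1`, which gives 895 nM. Within the data shown here, the only step measured, no change at the digits printed from compound 1 to compound 2 (within the scatter), swapped one amine-bearing group for another. Compound 3 `COc1ccc2c(c1)O/C(=C\c1ccc(OCCC3CCCC3)cc1)C2=O` differs from compound 2 by cyclopentyl in place of (dimethylamino)methyl on a saturated chain carbon, two bonds along the chain from an oxygen on an aromatic ring. Among the measured compounds shown here, no measured step removes the amine altogether, so the one step gives only weak guidance. The expected change, a 1.1-fold higher number from compound 2 to compound 3 (0.05 log units; within the scatter), is therefore small, in no firm direction. For compound 3 the estimate in this assay is 1000 nM, with a likely range from 300 nM to 3500 nM.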

Compound 3, half-maximal inhibitory concentration: 895 nM
Beside the measured number, compound 3's estimate is 1.1-fold (0.05 log units) above it; the range from low to high includes it.
By their numbers in this assay, from the lowest: compounds 1, 2 and 3 (each within the scatter of the next).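

Replacing (dimethylamino)methyl with cyclopentyl, a ring of carbon only, gives no change at the digits printed from compound 2 to compound 3 (within the scatter) in this assay, so at this chain end inhibition holds without the nitrogen that both earlier compounds carried. The wider swap of diethylamino for 2-cyclopentylethoxy on the aromatic carbon likewise gives no change at the digits printed from compound 1 to compound 3 (within the scatter) on the same read-out. No measurement here accounts for this sameness.

On these data alone, whether a carboxylic acid at the chain end would read the same remains open. So does the effect of a longer chain between the oxygen and the cyclopentyl ring.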